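Turning One Stereocentre on Compound 2

This account rests on a few compounds, and the source may have more. Where it says the series, first, only, none or still open, it means among the compounds named here.

In a functional assay on HCT-116 cells (Homo sapiens) for inhibition, read by MTT assay, with a stated time of 72 h (on this read-out higher numbers stand for weaker inhibition and lower numbers for stronger inhibition), compound 1 `CC1=NN(c2ccccc2)C(=O)[C@@]12C(=O)C=CC[C@@H]2c1ccccc1[N+](=O)[O-]` gives 66800 nM and compound 2 `CC1=NN(c2ccccc2)C(=O)[C@@]12C(=O)C=CC[C@H]2c1ccccc1` gives 4400 nM as the lower of the two numbers, a gap beyond the scatter. Compound 3 `CC1=NN(c2ccccc2)C(=O)[C@@]12C(=O)C=CC[C@@H]2c1ccccc1` is not yet measured and has the same atoms and bonds as compound 2 (the two compounds have the same atoms and bonds and differ only in configuration as drawn: 1 of 2 stereo elements differ; a stereocentre at a saturated ring carbon is drawn S in compound 2 and R in compound 3) so only its configuration as drawn differs. For the measured compounds named here, no measured pair shows what such a change does, so a moderate weakening in this assay is only a cautious expectation and could stay near the scatter. The expected move is a 2.0-fold higher number from compound 2 to compound 3 (0.31 log units; beyond the scatter) in this estimate. Compound 3 is estimated at 9000 nM with an expected range (2500 nM to 35000 nM).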

Compound 3, half-maximal inhibitory concentration: 6070 nM
Compound 3: middle estimate off by 1.5-fold (0.17 log units), on the high side; measured number inside the range.
By their numbers in this assay, from the lowest: compounds 2 and 3 (each within the scatter of the next); then compound 1.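

In this assay, turning this saturated ring carbon from S to R gives a 1.4-fold higher number from compound 2 to compound 3 (0.14 log units; within the scatter), so the drawn configuration here does not separate the two compounds. This comparison isolates a single stereocentre: the fact that compounds 2 and 3 differ only in the configuration as drawn. With the configuration matched, hydrogen in place of nitro on an aromatic carbon gives an 11-fold lower number from compound 1 to compound 3 (1.04 log units; beyond the scatter), so that change, unlike the turned stereocentre, has a large step.

Still open, from the compounds shown here alone, is what turning the second stereocentre would do. Also open, going by these compounds, is whether an amine or a carboxylic acid on that aromatic carbon would land nearer compound 3 or compound 1.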